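A few compounds are considered here, and "the series" means these few. Any claim that something is new, unique, unknown or untested is made for them only; others in the source may bear on it.

Compound 1 `CNCc1cn(S(=O)(=O)c2cccs2)c(-c2cccnc2F)c1F` is measured in a physicochemical assay for lipophilicity, read by HPLC, at pH 7.4 (a lower number here means a more polar compound, a higher number a more lipophilic compound), at 0.54. Among the three measured compounds it stands second highest: compound 2 `CNCc1cn(S(=O)(=O)c2ncccc2C)c(-c2cccnc2F)c1F` gives 0.32, and compound 3 `CNCc1cn(S(=O)(=O)c2cccc(F)n2)c(-c2cccnc2F)c1F` gives 0.7. The step of a number 0.22 log units lower from compound 1 to compound 2 (within the scatter) and the step of a number 0.16 log units higher from compound 1 to compound 3 (within the scatter) both stay within the scatter, while the step of a number 0.38 log units higher from compound 2 to compound 3 (beyond the scatter) goes beyond it.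

Compound 4 `CNCc1cn(S(=O)(=O)c2ccc(F)cn2)c(-c2cccnc2F)c1F` differs from compound 1 in one place: 5-fluoropyridin-2-yl in place of thiophen-2-yl on a sulfonyl sulfur. The closest guide is the step to compound 3, where a 6-fluoropyridin-2-yl also replaced thiophen-2-yl and the number moved a number 0.16 log units higher from compound 1 to compound 3 (within the scatter). A similar small shift is therefore expected, a number 0.11 log units higher from compound 1 to compound 4 (within the scatter), with no change beyond the scatter. Compound 4 is estimated at 0.65, between 0.35 and 0.95.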

Compound 4, distribution coefficient: 0.42
The estimate for compound 4 lay 0.23 log units above the measured number; low and high end bracket the measured number.
By their numbers in this assay, from the lowest: compounds 2, 4, 1 and 3 (each within the scatter of the next, the first and the last beyond it).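

On this sulfonyl sulfur in this assay, 5-fluoropyridin-2-yl in place of thiophen-2-yl gives a small step (a number 0.12 log units lower from compound 1 to compound 4 (within the scatter)), so this six-membered ring with its fluorine leaves the reading close to that of the five-membered ring. The same group in place of 6-fluoropyridin-2-yl (a number 0.28 log units lower from compound 3 to compound 4 (within the scatter)) or 3-methylpyridin-2-yl (a number 0.10 log units higher from compound 2 to compound 4 (within the scatter)) also stays close, so compound 4 is not separated from any of the other three compounds. No measurement shown offers an explanation for these small steps.

As far as these compounds go, whether a pyridine bearing an amine or a carboxylic acid on this sulfur would move the number beyond the scatter remains open.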